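Swapping a Piperazine for a Methylamide: Solubility Outlook

The compounds below may be only part of what the source reports. "The series", "measured", "known", "first", "only" and "open" are said of these compounds alone.

Among the compounds with values here, in a physicochemical assay for solubility, read by nephelometry (on this read-out lower numbers stand for lower solubility and higher numbers for higher solubility), compound 1 `CN1CCN(c2cc(CN3C(=O)N(c4ccc(SC(F)(F)F)cc4)C(=O)C3(C)C)ccn2)CC1` gives 0.159 ug/mL, the only plain number among the values at hand. Compound 2 `CC1(C)C(=O)N(c2ccc(SC(F)(F)F)cc2)C(=O)N1Cc1ccnc(Nc2ccccc2)c1` reaches only a limit of the assay, < 0.025 ug/mL. Within the data shown here, the single measured step, an at least 6.3-fold lower number from compound 1 to compound 2 (0.80 log units; beyond the scatter), shows that removing the 4-methylpiperazin-1-yl lowered solubility beyond the scatter, the result sitting at the limit of < 0.025 ug/mL in this assay, at which 1 of the 2 values shown sits. Compound 3 `CNC(=O)c1cc(CN2C(=O)N(c3ccc(SC(F)(F)F)cc3)C(=O)C2(C)C)ccn1` carries the change (methylcarbamoyl in place of 4-methylpiperazin-1-yl on an aromatic carbon), which again removes the 4-methylpiperazin-1-yl. A clear fall is therefore expected, a 4.0-fold lower number from compound 1 to compound 3 (0.60 log units; beyond the scatter). Compound 3 is estimated at 0.04 ug/mL, between 0.015 ug/mL and 0.12 ug/mL.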

Compound 3, solubility: < 0.023 ug/mL
Compound 3 ended at the assay's limit; the forecaster's own chance of this, stated with the estimate: 35%; at least 1.7-fold (0.24 log units) between middle value and limit.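

Putting methylcarbamoyl in place of 4-methylpiperazin-1-yl, on this aromatic carbon next to the ring nitrogen, gives an at least 6.9-fold lower number from compound 1 to compound 3 (0.83 log units; beyond the scatter) in this assay. A group with no ring thus lowers the read-out beyond the scatter here, just as the ring-bearing anilino of compound 2 did. The result for compound 3 is a limit of the assay, not a number: the limit of < 0.023 ug/mL in this assay, at which 1 of the 3 values shown sits.

Compound 2 and compound 3 both stand at limits, so the step between them cannot be read. As far as these compounds go, whether a simple amine or a carboxylic acid at this place would stay level with compound 1 remains open.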